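The source may hold more compounds than are shown below. What is called first, only, known or untested is meant among the compounds shown, and "the series" means these compounds.

Compound 2, `CCOc1cc(NC(=O)C2(NC(=O)c3ccc4c(C5CCCC5)c(-c5ncc(Cl)cn5)n(C)c4c3)CCC2)ccc1/C=C/C(=O)OCC(C)C`, gives 18 h in an ADME assay on a cell-free system (plasma, Rattus norvegicus) for pharmacokinetics (on this read-out higher numbers stand for a longer-lived compound and lower numbers for a shorter-lived compound), the higher of the two numbers recorded so far. Going by the values given here, compound 1, `CCOC(=O)/C=C/c1ccc(NC(=O)C2(NC(=O)c3ccc4c(C5CCCC5)c(-c5ncc(Cl)cn5)n(C)c4c3)CCC2)cc1OCC`, gives 8.18 h in this assay, and the single recorded step, a 2.2-fold higher number from compound 1 to compound 2 (0.34 log units; beyond the scatter), is the only comparison available. Compound 3, `CCOc1cc(NC(=O)C2(NC(=O)c3ccc4c(C5CCCC5)c(-c5ncc(Cl)cn5)n(C)c4c3)CCC2)ccc1/C=C/C(=O)OCC(Cl)(Cl)Cl`, has not yet been measured; it differs from compound 2 by trichloromethyl in place of isopropyl on a saturated chain carbon bound to an oxygen next to a carbonyl group. Among the compounds with values here, the one measured step concerns a different exchange at the same position and so bears on compound 3 only loosely: it shows that altering the group on this carbon can move the read-out by a modest amount, but it gives no guide to the direction for a trichloromethyl group. The step from compound 2 to compound 3 in this assay is therefore expected to be small, a 1.3-fold lower number from compound 2 to compound 3 (0.11 log units; within the scatter), with no clear direction. Compound 3 is estimated at 14 h in this assay, within a range from 5 h to 40 h.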

Compound 3, half-life: 1.3 h
Estimate against measurement, compound 3: 11-fold (1.03 log units) above, outside the stated range (below it).
By their numbers in this assay, from the lowest: compound 3; then compound 1; then compound 2.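

In this assay, the group on the saturated chain carbon bound to an oxygen next to a carbonyl group can move the read-out much further than the earlier pair suggested, which showed only a 2.2-fold higher number from compound 1 to compound 2 (0.34 log units; beyond the scatter). Trichloromethyl in place of isopropyl gives a 14-fold lower number from compound 2 to compound 3 (1.14 log units; beyond the scatter), and trichloromethyl in place of methyl gives a 6.3-fold lower number from compound 1 to compound 3 (0.80 log units; beyond the scatter), so changes at this carbon can lower the number as well as raise it, and compound 3 stands lowest of the three. Nothing measured here accounts for this drop.

The compounds shown leave open whether the drop follows from the chlorine atoms or from the trichloromethyl group as a whole, a question that trifluoromethyl, chloromethyl or a longer chain on this carbon would address. They also leave open how a carboxylic acid in place of the ester would read in this assay.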